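Series notes: 4-methylphenyl to 4-methoxyphenyl

The source may report more compounds than this note shows. Statements on the series, on what has been measured and on what is new or still open speak of the compounds shown alone.

In an ADME assay on MDBK cells (Bos taurus) for cytotoxicity (on this read-out higher numbers stand for lower toxicity in this test and lower numbers for higher toxicity in this test), the measured compounds read as follows
compound 1 `Cc1ccccc1Cn1ccc2nc(-c3ccccc3)nc-2c1` gives > 100000 nM
compound 2 `Cc1cccc(Cn2ccc3nc(-c4ccccc4)nc-3c2)c1` gives > 100000 nM
compound 3 `Cc1ccc(Cn2ccc3nc(-c4ccccc4)nc-3c2)cc1` gives > 100000 nM

Compound 3 stands only at a limit (> 100000 nM) and so carries no number. The two other measured values are limits too (the limit of > 100000 nM in this assay, at which 3 of the 3 values shown sit).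

The next compound, compound 4 `COc1ccc(Cn2ccc3nc(-c4ccccc4)nc-3c2)cc1`, has methoxy in place of methyl on an aromatic carbon, para to a large group (methoxy in place of methyl on an aromatic carbon). The measured steps exchange one methylphenyl for another, and none of them has a readable size (a step that the two limits leave unreadable from compound 1 to compound 2; a step that the two limits leave unreadable from compound 1 to compound 3; a step that the two limits leave unreadable from compound 2 to compound 3). None of them involves methoxy. With no readable step to go on, no step beyond the scatter is expected in this assay and no direction can be given. The expected step is small (a number no higher from compound 3 to compound 4 (the limit leaves the size open)). Compound 4 is estimated at 100000 nM with an expected range from 50000 nM to 200000 nM and will most likely be reported only as a limit.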

Compound 4, half-maximal cytotoxic concentration: > 100000 nM
Compound 4: only a limit was reported; the forecaster's own chance of this, stated with the estimate: 85%; the middle value lies on the limit itself.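

In this assay compound 4 gives > 100000 nM, a limit and not a number. Among these compounds, no step linking compound 4 to compound 1, compound 2 or compound 3 can be read. The compounds shown leave open whether methoxy in place of methyl changes this read-out at all, and the size of any difference among them: the limit of > 100000 nM in this assay, at which 4 of the 4 values shown sit.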